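The compounds below may be only part of what the source reports. "The series", "measured", "known", "first", "only" and "open" are said of these compounds alone.

Compound 1 `O=C(O)CCc1ccc(OCc2nc(-c3ccccc3)no2)cc1` gives 1130 nM.
Compound 2 `COc1cccc(-c2noc(COc3ccc(CCC(=O)O)cc3)n2)c1` gives 2670 nM.
Compound 3 `O=C(O)CCc1ccc(OCc2nc(-c3ccc(C(F)(F)F)cc3)no2)cc1` gives 610 nM.

In a functional assay on CHO cells for agonist activity at Free fatty acid receptor 1 (Homo sapiens), read by FLIPR and calcium flux, in the presence of a further agent that is not named here (on this read-out higher numbers stand for an effect only at larger amounts of compound and lower numbers for an effect already at smaller amounts), compound 1 stands second highest of the three numbers. Its nearest neighbour is compound 3, reached by a 1.9-fold lower number from compound 1 to compound 3 (0.27 log units; within the scatter), and its furthest is compound 2, reached by a 2.4-fold higher number from compound 1 to compound 2 (0.37 log units; beyond the scatter). Both of these steps add a small group onto an aromatic carbon of the shared core, and only the methoxy step moved the number beyond the scatter, while the trifluoromethyl step stayed within it.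

Compound 4 `O=C(O)CCc1ccc(OCc2nc(-c3ccccc3)no2)c(Cl)c1` is the next candidate. It differs from compound 1 by chloro in place of hydrogen on an aromatic carbon, the new chloro sitting ortho to a large group and meta to the 2-carboxyethyl group. Neither measured step touches this part of the shared core, so they bear on it only loosely: they show that a single small group added to an aromatic carbon has so far shifted the number modestly at most, in either direction. On that basis a step of no more than modest size is expected in this assay, with the direction uncertain. Compound 4 is therefore estimated at 900 nM, within a range of 400 nM to 2500 nM. This estimate amounts to an expected 1.3-fold lower number from compound 1 to compound 4 (0.10 log units; within the scatter).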

Compound 4, half-maximal effective concentration: 13100 nM
Estimate against measurement, compound 4: 15-fold (1.16 log units) below, and the stated range ends below it.
By their numbers in this assay, from the lowest: compounds 3 and 1 (each within the scatter of the next); then compound 2; then compound 4.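

The chloro group, sitting ortho to a large group and meta to a 2-carboxyethyl group, produces by far the biggest change so far in this assay, with a 12-fold higher number from compound 1 to compound 4 (1.06 log units; beyond the scatter). The earlier changes lay elsewhere on the shared core and gave only a 2.4-fold higher number from compound 1 to compound 2 (0.37 log units; beyond the scatter) and a 1.9-fold lower number from compound 1 to compound 3 (0.27 log units; within the scatter), so this position is the first shown where adding one heavy atom, a chlorine, moves the number by a large amount, and the size of a step at one place clearly does not carry over to another. Nothing measured here explains why this single replacement has such a large effect.

On these data alone, it remains open whether this result is specific to chloro or would apply to other groups on the same aromatic carbon, and a fluoro, a methyl or a methoxy there would help separate those two readings. Also open, as far as these compounds go, is whether chloro on other carbons of this ring would give a similar step, and whether it would have the same effect in a compound that also carries the trifluoromethyl group of compound 3.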